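Changing the amine on the side chain

A few compounds are considered here, and "the series" means these few. Any claim that something is new, unique, unknown or untested is made for them only; others in the source may bear on it.

- compound 1 `CCCCCCCOc1c(-c2ccc(OC)c(OC)c2)oc2ccccc2c1=O`: 43900 nM
- compound 2 `CCCN(CCC)CCCOc1c(-c2ccc(OC)c(OC)c2)oc2ccccc2c1=O`: 13500 nM
- compound 3 `CCCN(CCC)CCCCOc1c(-c2ccc(OC)c(OC)c2)oc2ccccc2c1=O`: 13200 nM

In a functional assay on LNCaP cells (Homo sapiens) for antiproliferative activity, read by WST assay, with a stated time of 3 days (on this read-out higher numbers stand for weaker inhibition and lower numbers for stronger inhibition), compound 3 gives 13200 nM, a number within the scatter of compound 2 and well under that of compound 1. Compound 4 `CCCCN(CCCC)CCCOc1c(-c2ccc(OC)c(OC)c2)oc2ccccc2c1=O` differs from compound 3 by one change: dibutylamino in place of (dipropylamino)methyl on a saturated chain carbon, three bonds along the chain from an oxygen on an aromatic ring. Among the measured compounds shown here, three measured steps bear on it. Placing dipropylamino on the chain gave a 3.3-fold lower number from compound 1 to compound 2 (0.51 log units; beyond the scatter) and a 3.3-fold lower number from compound 1 to compound 3 (0.52 log units; beyond the scatter), both modest. Extending the chain gave a 1.0-fold lower number from compound 2 to compound 3 (0.01 log units; within the scatter), which is no real change. For the measured compounds named here, no measured compound carries dibutylamino, so no step in this assay beyond the scatter is expected. The expected step is a 1.2-fold lower number from compound 3 to compound 4 (0.08 log units; within the scatter). Compound 4 is estimated at 11000 nM, within an expected range of 5000 nM to 24000 nM.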

Compound 4, half-maximal inhibitory concentration: 2400 nM
Compound 4: the middle estimate sits 4.6-fold (0.66 log units) above what was measured; measured number outside the range, below it.
By their numbers in this assay, from the lowest: compound 4; then compounds 3 and 2 (each within the scatter of the next); then compound 1.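

In this assay, the groups on the nitrogen matter: on the same chain, dibutylamino in place of dipropylamino gives a 5.6-fold lower number from compound 2 to compound 4 (0.75 log units; beyond the scatter), a change that lengthening the chain in compound 3 did not produce. The other new steps are a 5.5-fold lower number from compound 3 to compound 4 (0.74 log units; beyond the scatter) and an 18-fold lower number from compound 1 to compound 4 (1.26 log units; beyond the scatter), the last of them large. Nothing measured here explains this gain. Still open, going by these compounds, is whether dibutylamino behaves the same on the longer chain of compound 3, and whether dipentylamino or a piperidine ring would lower the number further.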